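This account rests on a few compounds, and the source may have more. Where it says the series, first, only, none or still open, it means among the compounds named here.

Compound 1 `COc1cc(C(=O)C2Sc3nnc(-c4cc(OC)c(OC)c(OC)c4)n3NC2c2ccco2)cc(OC)c1OC` is the reference point of this small set; in a functional assay on A549 cells (Homo sapiens) for cytotoxicity, read by MTT assay, with a stated time of 48 h (on this read-out higher numbers stand for weaker inhibition and lower numbers for stronger inhibition), compound 1 gives 48300 nM, the highest of the three numbers. Compound 2 `COc1cc(-c2nnc3n2NC(c2ccco2)C(C(=O)c2ccc(Br)cc2)S3)cc(OC)c1OC` gives 42100 nM and compound 3 `COc1cc(-c2nnc3n2NC(c2cccs2)C(C(=O)c2ccc(F)cc2)S3)cc(OC)c1OC` gives 45000 nM; both lie within the scatter of compound 1, so no order among the three can be read.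

Compound 4 `COc1cc(-c2nnc3n2NC(c2ccco2)C(C(=O)c2cccc4ccccc24)S3)cc(OC)c1OC` has not been measured. The change from compound 1 is naphthalen-1-yl in place of 3,4,5-trimethoxyphenyl on a carbonyl carbon. Among the measured compounds shown here, the one measured step of the same kind, an aryl swap on the carbonyl carbon, is a 1.1-fold lower number from compound 1 to compound 2 (0.06 log units; within the scatter), which gave no movement beyond the scatter. On that basis a step of a 1.1-fold lower number from compound 1 to compound 4 (0.03 log units; within the scatter) is expected, that is, none beyond the scatter. The value of compound 4 is therefore estimated at 45000 nM, with a range from 24000 nM to 90000 nM.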

Compound 4, half-maximal inhibitory concentration: > 100000 nM
Compound 4: a limit, no number; the forecaster's own chance of this, stated with the estimate: 15%; at least 2.2-fold (0.34 log units) between middle value and limit.
By their numbers in this assay, from the lowest: compounds 2, 3 and 1 (each within the scatter of the next). At a limit, above all of these: compound 4.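

Compound 4 in this assay gives no number, only a limit of the assay: the limit of > 100000 nM in this assay, at which 1 of the 4 values shown sits.
Among the compounds shown here, this is the first aryl swap on the carbonyl carbon to reach beyond the scatter, with an at least 2.0-fold higher number from compound 1 to compound 4 (0.31 log units; beyond the scatter) and an at least 2.3-fold higher number from compound 2 to compound 4 (0.37 log units; beyond the scatter).
The position therefore does not accept every aryl group alike: naphthalen-1-yl separates from both 3,4,5-trimethoxyphenyl and 4-bromophenyl, which themselves stay within the scatter of each other.
Open, going by these compounds, is whether a methyl group, or a phenyl carrying an amine or a carboxylic acid, on the carbonyl carbon would stay with compound 1 or go with compound 4.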